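A few compounds are considered here, and "the series" means these few. Any claim that something is new, unique, unknown or untested is made for them only; others in the source may bear on it.

Measured compounds:
Compound 1 `O=C(COc1ccc(F)cc1)Nc1nc(-c2ccc(Br)cc2)cs1` — 45500 nM
Compound 2 `Cc1ccc(-c2csc(NC(=O)COc3ccc(F)cc3)n2)cc1` — 18400 nM
Compound 3 `Cc1ccc(OCC(=O)Nc2nc(-c3ccc(C)cc3)cs2)cc1` — 45700 nM

Three compounds were tested in a functional assay on Ehrlich cells (Mus musculus) for cytotoxicity, read by MTT assay, with a stated time of 48 h; on this read-out higher numbers stand for weaker inhibition and lower numbers for stronger inhibition. In this assay compound 2 gives 18400 nM, compound 1 gives 45500 nM and compound 3 gives 45700 nM. The values of compound 1 and compound 3 lie within the scatter of each other, so no order between them can be read. Compound 2 stands apart from both: the step of a 2.5-fold higher number from compound 2 to compound 1 (0.39 log units; beyond the scatter) reflects the change (bromo in place of methyl on an aromatic carbon), and the step of a 2.5-fold higher number from compound 2 to compound 3 (0.40 log units; beyond the scatter) reflects the change (methyl in place of fluoro on an aromatic carbon).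

The unmeasured compound 4 `Cc1ccc(OCC(=O)Nc2nc(-c3ccc(Br)cc3)cs2)cc1` is related to compound 3 by the change (bromo in place of methyl on an aromatic carbon). This is the same change that carries compound 2 to compound 1, and the place line of each is identical, so the two changes are the same. The cores of compound 3 and compound 2 differ by methyl in place of fluoro on an aromatic carbon.

From compound 3 to compound 4 a step close to the earlier one is expected, namely a 2.3-fold higher number from compound 3 to compound 4 (0.36 log units; beyond the scatter), because in compound 2 the same change produced a 2.5-fold higher number from compound 2 to compound 1 (0.39 log units; beyond the scatter). For the measured compounds named here, whether the two changes add up in this way rests on only one measured pair, so the expectation is uncertain. Compound 4 is estimated to give 105000 nM in this assay, expected between 50000 nM and 220000 nM.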

Compound 4, half-maximal inhibitory concentration: 55800 nM
Estimate against measurement, compound 4: 1.9-fold (0.27 log units) above, within the range that was stated.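

In this assay, bromo in place of methyl on the core of compound 3 gives a 1.2-fold higher number from compound 3 to compound 4 (0.09 log units; within the scatter), and set beside the same change on the core of compound 2, this shows no difference that can be claimed: the same change on two cores in this assay, a 2.5-fold higher number (0.39 log units; beyond the scatter) from compound 2 to compound 1 and a 1.2-fold higher number (0.09 log units; within the scatter) from compound 3 to compound 4, 2.0-fold (0.31 log units) apart, within the scatter of two such steps Methyl in place of fluoro, carried to the core bearing the 4-bromophenyl group, gives a 1.2-fold higher number from compound 1 to compound 4 (0.09 log units; within the scatter), and again no difference between the two cores can be claimed: the same change on two cores in this assay, a 2.5-fold higher number (0.40 log units; beyond the scatter) from compound 2 to compound 3 and a 1.2-fold higher number (0.09 log units; within the scatter) from compound 1 to compound 4, 2.0-fold (0.31 log units) apart, within the scatter of two such steps Both changes are therefore compatible with carrying over from one core to the other, but this does not show that either step is constant, since each comparison rests on just two steps and each change lies beyond the scatter on one core and within it on the other.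

The compounds shown leave open how a nitrile, a methoxy group or an amine on these aromatic rings would read in this assay, and whether a longer chain in the link to the amide would leave these steps as they stand. Going by these compounds, it also remains open whether either change would behave in the same way on any core other than these.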